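The source may hold more compounds than are shown below. What is called first, only, known or untested is meant among the compounds shown, and "the series" means these compounds.

Compound 1 `COCCn1nc(C(=O)N[C@H]2COc3ccccc3N(C)C2=S)nc1Cc1ccccc1` in a functional assay on HT-29 cells (Homo sapiens) for inhibition, read by luminescence and CellTiter-Glo, with a stated time of 24 h; a lower number here means that less compound is needed, a higher number that more compound is needed for the effect: 566 nM
Compound 2 `CN1C(=S)[C@@H](NC(=O)c2nc(Cc3ccccc3)n(C3CCCCC3)n2)COc2ccccc21` in this assay: 4000 nM

Among the measured compounds shown here, compound 2 stands at the higher of these two numbers, the only step known being a 7.1-fold higher number from compound 1 to compound 2 (0.85 log units; beyond the scatter). Compound 3 `Cc1cnc(-n2nc(C(=O)N[C@H]3COc4ccccc4N(C)C3=S)nc2Cc2ccccc2)nc1` has no measurement in this assay and differs from compound 2 by 5-methylpyrimidin-2-yl in place of cyclohexyl on an aromatic nitrogen. For the measured compounds named here, no measured step covers this exact change; the one step available shows that cyclohexyl on this aromatic nitrogen went with the higher number, so its removal is expected to bring a modest lowering, a 2.7-fold lower number from compound 2 to compound 3 (0.43 log units; beyond the scatter). Compound 3 is therefore estimated at 1500 nM, within a range from 400 nM to 6000 nM.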

Compound 3, half-maximal effective concentration: 1950 nM
Estimate against measurement, compound 3: 1.3-fold (0.11 log units) below; the measured number falls inside the stated range.
By their numbers in this assay, from the lowest: compound 1; then compound 3; then compound 2.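

In this assay the step of a 2.1-fold lower number from compound 2 to compound 3 (0.31 log units; beyond the scatter) on replacing cyclohexyl with 5-methylpyrimidin-2-yl shows that the number at this aromatic nitrogen depends on which six-membered ring sits there, not merely on a ring being present. The 2-methoxyethyl chain still gives the lowest number of the three, since the step of a 3.4-fold higher number from compound 1 to compound 3 (0.54 log units; beyond the scatter) is also beyond the scatter. Nothing measured explains these differences.

Still open, from the compounds shown here alone, is how a plain phenyl ring would compare with these two rings. Also open, going by these compounds, is whether a methyl group or a longer ether chain could go below compound 1.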